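This account rests on a few compounds, and the source may have more. Where it says the series, first, only, none or still open, it means among the compounds named here.

In an ADME assay on NHDF cells (Homo sapiens) for cytotoxicity, read by MTT assay, with a stated time of 72 h (a higher number here means a weaker inhibitor, a lower number a stronger inhibitor), three compounds on a shared core have been read: compound 1 (`COc1ccc(/C=C2\CCC/C(=C\c3ccc(Cl)cc3)C2=O)cc1OC`) gives 11200 nM, compound 2 (`COc1ccccc1/C=C1\CCC/C(=C\c2ccc(OC)c(OC)c2)C1=O`) gives 18100 nM and compound 3 (`COc1cc(/C=C2\CCC/C(=C\c3ccc(OC)c(OC)c3)C2=O)ccc1O`) gives 13700 nM. Compound 3 stands level with the other two, and the gap between those two, a 1.6-fold higher number from compound 1 to compound 2 (0.21 log units; within the scatter), is also small. Compound 4 (`COc1ccc(/C=C2\CCC/C(=C\c3ccc(O)c(O)c3)C2=O)cc1OC`) differs from compound 3 by hydrogen in place of methyl on an oxygen on an aromatic ring, giving 3,4-dihydroxyphenyl from 4-hydroxy-3-methoxyphenyl. For the measured compounds named here, no measured step makes this exact change. The closest ones, a 1.2-fold higher number from compound 1 to compound 3 (0.09 log units; within the scatter) and a 1.3-fold lower number from compound 2 to compound 3 (0.12 log units; within the scatter), are small, so no step beyond the scatter is expected in this assay. The expected step is a 1.2-fold lower number from compound 3 to compound 4 (0.10 log units; within the scatter). For compound 4 the estimated value is 11000 nM, with an expected range of 5000 nM to 22000 nM.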

Compound 4, half-maximal inhibitory concentration: 25200 nM
The estimate for compound 4 lay 2.3-fold (0.36 log units) below the measured number; the whole stated range lies below it.
By their numbers in this assay, from the lowest: compounds 1, 3, 2 and 4 (each within the scatter of the next, the first and the last beyond it).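

In this assay, methoxy to hydroxy on the 4-hydroxy-3-methoxyphenyl group, read directly here for the only time (a 1.8-fold higher number from compound 3 to compound 4 (0.26 log units; within the scatter)), stays within the scatter, as does the swap from 2-methoxyphenyl to 3,4-dihydroxyphenyl (a 1.4-fold higher number from compound 2 to compound 4 (0.14 log units; within the scatter)). For the compounds shown here, the same group in place of 4-chlorophenyl gives the only modest step beyond the scatter (a 2.3-fold higher number from compound 1 to compound 4 (0.35 log units; beyond the scatter)). No available evidence bears on this result.

Open, going by these compounds, is whether an amine or a carboxylic acid in place of the hydroxy would separate further from compound 1 in this assay. A single comparison cannot show whether the step belongs to the 3,4-dihydroxyphenyl group or to the loss of 4-chlorophenyl.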